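Dipropylamino for Piperidinyl on the Tert-Butyl Core

This account rests on a few compounds, and the source may have more. Where it says the series, first, only, none or still open, it means among the compounds named here.

Measured so far in a physicochemical assay for solubility, in the presence of a further agent that is not named here; on this read-out lower numbers stand for lower solubility and higher numbers for higher solubility:
Compound 1, `Cc1ccc2c(c1)[n+]([O-])c(NCCN1CCCCC1)n[n+]2[O-]`, gives 45000000 nM.
Compound 2, `CCCN(CCC)CCNc1n[n+]([O-])c2ccc(C)cc2[n+]1[O-]`, gives 38000000 nM.
Compound 3, `CC(C)(C)c1ccc2c(c1)[n+]([O-])c(NCCN1CCCCC1)n[n+]2[O-]`, gives 28000000 nM.

Compound 1 and compound 2 differ by dipropylamino in place of piperidin-1-yl on a saturated chain carbon, two bonds along the chain from a nitrogen on an aromatic ring, and this change produced a 1.2-fold lower number from compound 1 to compound 2 (0.07 log units; within the scatter). The two cores differ by tert-butyl in place of methyl on an aromatic carbon, which gave a 1.6-fold lower number from compound 1 to compound 3 (0.21 log units; within the scatter). Compound 3 sits within the scatter of both compound 1 and compound 2, so no order among the three can be read from these numbers.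

Compound 4, `CCCN(CCC)CCNc1n[n+]([O-])c2ccc(C(C)(C)C)cc2[n+]1[O-]`, has not been measured. It differs from compound 3 by dipropylamino in place of piperidin-1-yl on a saturated chain carbon, two bonds along the chain from a nitrogen on an aromatic ring. Since the place of this change is the same, word for word, as the place of the change from compound 1 to compound 2, it is the same change made on the other core.

Within the data shown here, on that basis the step from compound 3 to compound 4 is expected to be small, a 1.2-fold lower number from compound 3 to compound 4 (0.09 log units; within the scatter), beside the measured 1.2-fold lower number from compound 1 to compound 2 (0.07 log units; within the scatter), because the only measured instance of this change gave a 1.2-fold lower number from compound 1 to compound 2 (0.07 log units; within the scatter). Compound 4 is therefore estimated at 23000000 nM in this assay, with a likely range from 12000000 nM to 45000000 nM.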

Compound 4, solubility: 32000000 nM
The estimate for compound 4 lay 1.4-fold (0.14 log units) below the measured number; measured number inside the range.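

On the core of compound 3, dipropylamino in place of piperidin-1-yl gave a small step in this assay (a 1.1-fold higher number from compound 3 to compound 4 (0.06 log units; within the scatter)), and the same change on the core of compound 1 was also small (a 1.2-fold lower number from compound 1 to compound 2 (0.07 log units; within the scatter)), so on both cores the step lies within the scatter and no direction can be read from either. The change of core, tert-butyl in place of methyl on an aromatic carbon, likewise stays within the scatter on the dipropylamino side (a 1.2-fold lower number from compound 2 to compound 4 (0.07 log units; within the scatter)); this shows that the change carried over between these two cores without a step beyond the scatter, but it does not show that the change does nothing, or that it would carry to any other core. No measurement shown here bears on why these numbers lie so close together.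

As far as these compounds go, what remains open is whether the step stays this small when morpholin-4-yl or dimethylamino stands in place of piperidin-1-yl, or when a longer chain carries the amine. From the compounds shown here alone, it is also open whether the change carries over to a core with a carboxylic acid in place of tert-butyl on the aromatic carbon.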